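A few compounds are considered here, and "the series" means these few. Any claim that something is new, unique, unknown or untested is made for them only; others in the source may bear on it.

Measured so far in a functional assay on HL-60 cells (Homo sapiens) for antiproliferative activity, read by sulforhodamine B assay, with a stated time of 72 h; a lower number here means a stronger inhibitor, a higher number a weaker inhibitor:
compound 1, `S=C(NCc1ccccc1)N/N=C/c1ccc2ccccc2n1`: 21900 nM
compound 2, `NC(=S)N/N=C/c1cnc2ccccc2n1`: > 100000 nM

For compound 2 the value given is a limit of this assay rather than a number. For the measured compounds named here, compound 1 thus stands as the only compound with a measured number; the remaining entry is a limit (the limit of > 100000 nM in this assay, at which 1 of the 2 values shown sits). Going by the values given here, no step between two measured compounds is available, so the size of any move in this assay cannot be read off and has to be estimated. Compound 3, `S=C(N/N=C/c1ccc2ccccc2n1)Nc1ccc(Br)cc1`, differs from compound 1 in one place: 4-bromophenyl in place of benzyl on an amide-type nitrogen. Without a measured step to lean on, a change of this kind is expected to shift the value by little more than the scatter, perhaps slightly toward stronger inhibition. Compound 3 is therefore estimated to give 15000 nM in this assay, with a range from 5000 nM to 50000 nM, which amounts to an expected 1.5-fold lower number from compound 1 to compound 3 (0.16 log units; within the scatter).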

Compound 3, half-maximal inhibitory concentration: 27500 nM
Compound 3: the middle estimate sits 1.8-fold (0.26 log units) below what was measured; measured number inside the range.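

In this assay, putting 4-bromophenyl in place of benzyl on the amide-type nitrogen gives a 1.3-fold higher number from compound 1 to compound 3 (0.10 log units; within the scatter) and so leaves the read-out effectively unchanged. This first measured step shows that, for this pair, the two groups cannot be told apart in this test, even though they share the same heavy-atom count and one six-membered aromatic ring of carbon only, while one of them carries a bromine. Nothing measured here explains why the two groups read alike.

A plain phenyl group on the same nitrogen would help to separate the effect of the bromine from that of the benzyl carbon. A group of a different kind there, such as a carboxylic acid or a longer chain ending in an amine, would test whether this position can move the read-out at all.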